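The source may hold more compounds than are shown below. What is called first, only, known or untested is meant among the compounds shown, and "the series" means these compounds.

Working notes on the series. Compound 1 `O=C1C[C@H](OCc2cn(C(=O)c3ccccc3)nn2)[C@H]2CO[C@@H]1O2` bears benzoyl on the aromatic nitrogen, compound 2 `O=C1C[C@H](OCc2cn(-c3ccc(F)cc3)nn2)[C@H]2CO[C@@H]1O2` 4-fluorophenyl and compound 3 `CCCCn1cc(CO[C@H]2CC(=O)[C@@H]3OC[C@H]2O3)nn1` butyl; the rest of the molecule is the same in all three. In a functional assay on MDA-MB-231 cells (Homo sapiens) for cytotoxicity, read by MTT assay, with a stated time of 48 h (on this read-out lower numbers stand for stronger inhibition and higher numbers for weaker inhibition), compound 1 gives 25900 nM, compound 2 gives 23700 nM and compound 3 gives 27900 nM. Compound 3 stands within the scatter of both others: the steps of a 1.1-fold higher number from compound 1 to compound 3 (0.03 log units; within the scatter) and a 1.2-fold higher number from compound 2 to compound 3 (0.07 log units; within the scatter) are small, as is a 1.1-fold lower number from compound 1 to compound 2 (0.04 log units; within the scatter), so no order can be read among the three.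

Compound 4 `O=C1C[C@H](OCc2cn(-c3ccccc3Br)nn2)[C@H]2CO[C@@H]1O2` differs from compound 3 by 2-bromophenyl in place of butyl on an aromatic nitrogen. The step bearing on it most directly is a 1.2-fold higher number from compound 2 to compound 3 (0.07 log units; within the scatter), the same aryl-for-alkyl exchange run backwards, which stayed within the scatter; a 1.1-fold higher number from compound 1 to compound 3 (0.03 log units; within the scatter) was likewise within the scatter. No movement beyond the scatter is therefore expected in this assay for the new aryl group. Compound 4 is expected to give 25000 nM, with a range from 11000 nM to 55000 nM. The estimate for compound 4 means a step of a 1.1-fold lower number from compound 3 to compound 4 (0.05 log units; within the scatter), expected to remain within the scatter.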

Compound 4, half-maximal inhibitory concentration: 22500 nM
Estimate against measurement, compound 4: 1.1-fold (0.05 log units) above, and the stated range covers the measured number.
By their numbers in this assay, from the lowest: compounds 4, 2, 1 and 3 (each within the scatter of the next).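

In this assay the 2-bromophenyl group on the aromatic nitrogen adds a halogen-bearing aryl ring to the series, and the steps of a 1.2-fold lower number from compound 3 to compound 4 (0.09 log units; within the scatter) and a 1.1-fold lower number from compound 2 to compound 4 (0.02 log units; within the scatter) and a 1.2-fold lower number from compound 1 to compound 4 (0.06 log units; within the scatter) all remain within the scatter. This position has now carried butyl, benzoyl, 4-fluorophenyl and 2-bromophenyl with no order readable among compounds 1 to 4, so neither the swap of butyl for an aryl ring nor the bromine on that ring separates compound 4 from the others. No measured evidence is available that bears on this flat result.

From the compounds shown here alone, whether a group of another kind at this nitrogen, such as a phenyl ring carrying an amine or a carboxylic acid, or a chain longer than butyl, would move the number beyond the scatter remains open. Also open, going by these compounds, is whether any change to the shared core would do so.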